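Fluoro to Methoxy Exchange and Vero Cell Cytotoxicity

A few compounds are considered here, and "the series" means these few. Any claim that something is new, unique, unknown or untested is made for them only; others in the source may bear on it.

Three compounds have been measured in an ADME assay on Vero cells (Chlorocebus sabaeus) for cytotoxicity, read by neutral red uptake, tested at 394 ug/mL; on this read-out higher numbers stand for a weaker effect at the one concentration tested and lower numbers for a stronger effect:

Compound 1 `COc1ccc(C2SCC(=O)N2CCN2CCCCC2)cc1`: 73%
Compound 2 `O=C1CSC(c2ccc(F)cc2)N1CCN1CCCCC1`: 52%
Compound 3 `O=C1CSC(c2cccc(F)c2)N1CCN1CCCCC1`: 60%

Compound 2 and compound 3 have the same atoms, joined differently: 3-fluorophenyl in place of 4-fluorophenyl on a saturated ring carbon. The step of a number 8 percentage points higher from compound 2 to compound 3 (within the scatter). From compound 2 to compound 1 the change is methoxy in place of fluoro on an aromatic carbon, and here the step is larger: a number 21 percentage points higher from compound 2 to compound 1 (beyond the scatter). Compound 3 stands second of the three numbers in this assay, close to compound 2 and further from compound 1.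

Compound 4 `COc1cccc(C2SCC(=O)N2CCN2CCCCC2)c1` has not yet been measured in this assay. It differs from compound 3 by methoxy in place of fluoro on an aromatic carbon. This is the same kind of change as that from compound 2 to compound 1, though not the same: there the methoxy sits para to a large group, here meta to a large group. Because the earlier exchange gave a number 21 percentage points higher from compound 2 to compound 1 (beyond the scatter), a step in the same direction is expected from compound 3 to compound 4, a number 15 percentage points higher from compound 3 to compound 4 (beyond the scatter), somewhat smaller given the different place. Compound 4 is therefore estimated at 75%, with a range from 60% to 90%.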

Compound 4, a percentage reported as activity, at one concentration (the size of the read-out at that concentration, not a potency): 57%
Compound 4: middle estimate off by 18 percentage points, on the high side, and the stated range ends above it.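

In this assay, going by these compounds alone, methoxy in place of fluoro, meta to a large group, gives a number 3 percentage points lower from compound 3 to compound 4 (within the scatter), so this exchange yields no step that can be told apart from the usual scatter on this core. The exchange therefore does not carry over as a fixed increment from one core to the other, as the two steps are clearly different: the same change on two cores in this assay, a number 21 percentage points higher (beyond the scatter) from compound 2 to compound 1 and a number 3 percentage points lower (within the scatter) from compound 3 to compound 4, 24 percentage points apart, beyond the scatter of two such steps. Within the data shown here, this does not show why the two steps part, and with only two pairs at hand it cannot say which of them is the more typical of the series.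

The compounds shown leave open how other groups on the aromatic ring, such as chloro, nitrile or a carboxylic acid, would read in this assay at either place. They also leave open whether a longer chain in the side arm of the shared core would alter either step.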